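Swapping a methoxy for chloro on the benzyl amide

A few compounds are considered here, and "the series" means these few. Any claim that something is new, unique, unknown or untested is made for them only; others in the source may bear on it.

Measured compounds:
- compound 1, `COc1ccc(CNC(=O)/C=C/C=C/[C@H](O)Cc2ccc(OC)c(OC)c2)cc1`: 26600 nM
- compound 2, `COc1ccc(C[C@@H](O)/C=C/C=C/C(=O)N2CCN(c3ccccn3)CC2)cc1OC`: 23600 nM
- compound 3, `COc1ccc(C[C@@H](O)/C=C/C=C/C(=O)N2CCN(C(c3ccccc3)c3ccccc3)CC2)cc1OC`: 12500 nM

All three share a dienamide core carrying a secondary alcohol and a dimethoxyphenyl group, and differ only in the amide portion. In a functional assay on MCF7 cells (Homo sapiens) for antiproliferative activity, read by sulforhodamine B assay, with a stated time of 48 h (a higher number here means a weaker inhibitor, a lower number a stronger inhibitor), compound 1 gives 26600 nM, the highest number of the three. Compound 2 gives 23600 nM, which lies within the scatter of compound 1, so the two cannot be told apart. Compound 3 gives 12500 nM, a lower number that lies beyond the scatter of compound 1.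

Compound 4, `COc1ccc(C[C@@H](O)/C=C/C=C/C(=O)NCc2ccc(Cl)cc2)cc1OC`, is compound 1 with one change: chloro in place of methoxy on an aromatic carbon. Cut one bond further out, the difference reads 4-methoxybenzyl to 4-chlorobenzyl. Within the data shown here, no pair of measured compounds shows this exact step, so there is no direct guide to its size. Among the measured compounds shown here, since compound 4 keeps the benzyl amide of compound 1 and changes only one small group, the step is expected to be small, at most a modest move toward a lower number and possibly none beyond the scatter. The expected step from compound 1 to compound 4 in this assay is a 1.3-fold lower number from compound 1 to compound 4 (0.12 log units; within the scatter). Compound 4 is therefore estimated at 20000 nM, with a range from 8000 nM to 50000 nM.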

Compound 4, half-maximal inhibitory concentration: 18100 nM
For compound 4 the middle estimate is 1.1-fold (0.04 log units) above the measured one; low and high end bracket the measured number.
By their numbers in this assay, from the lowest: compounds 3, 4, 2 and 1 (each within the scatter of the next, the first and the last beyond it).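

In this assay, the swap of 4-methoxybenzyl for 4-chlorobenzyl gives a 1.5-fold lower number from compound 1 to compound 4 (0.17 log units; within the scatter), so the two groups cannot be told apart at this place on the ring. The earlier compounds shown here differ across the whole amide portion and could not isolate a single small group on the benzyl amide as this pair does. Nothing available explains this outcome or links it to any property of methoxy or chloro.

From the compounds shown here alone, what remains open is whether a group of another kind at this place, such as an amine, a carboxylic acid or a nitrile, would shift the number beyond the scatter. Going by these compounds, it is also open whether the same swap would give a similar result with the amide portion of compound 3 in place of the benzyl amide.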